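Selenium in Place of Sulfur on a Larger Core

This account rests on a few compounds, and the source may have more. Where it says the series, first, only, none or still open, it means among the compounds named here.

Compound 1 `CS/C(=N\C(=O)c1ccno1)NC(=O)c1ccno1` carries a methylsulfanyl group on a carbon with a double bond to nitrogen. In a functional assay on K562 cells (Homo sapiens) for cytotoxicity, read by MTT assay, with a stated time of 72 h (a lower number here means a stronger inhibitor of growth, a higher number a weaker inhibitor of growth), compound 1 gives only a limit of the assay, > 100000 nM. Compound 2 `C[Se]/C(=N\C(=O)c1ccno1)NC(=O)c1ccno1` differs by a group of 2 heavy atoms (1 carbon, 1 selenium; no ring) in place of a group of 2 heavy atoms (1 carbon, 1 sulfur; no ring), on a carbon with a double bond to nitrogen, and in this assay compound 2 gives 45600 nM. That change made an at least 2.1-fold lower number from compound 1 to compound 2 (0.34 log units; beyond the scatter). Compound 3 `CS/C(=N\C(=O)c1cc(-c2ccccc2)nc2ccccc12)NC(=O)c1cc(-c2ccccc2)nc2ccccc12` has a different core; the difference between the two cores is not broken down here. In this assay compound 3 gives only a limit, > 100000 nM. Compound 4 `C[Se]/C(=N\C(=O)c1cc(-c2ccccc2)nc2ccccc12)NC(=O)c1cc(-c2ccccc2)nc2ccccc12` is not yet measured and differs from compound 3 by the same change, (a group of 2 heavy atoms (1 carbon, 1 selenium; no ring) in place of a group of 2 heavy atoms (1 carbon, 1 sulfur; no ring), on a carbon with a double bond to nitrogen). From the compounds shown here alone, the earlier step rests against (the limit of > 100000 nM in this assay, at which 2 of the 3 values shown sit), so its true size is unknown. The step is expected to be an at least 1.4-fold lower number from compound 3 to compound 4 (0.15 log units; that floor lies within the scatter) because an at least 2.1-fold lower number from compound 1 to compound 2 (0.34 log units; beyond the scatter) was at least modest. Compound 4 is expected to give 70000 nM, somewhere between 20000 nM and 300000 nM.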

Compound 4, concentration for total growth inhibition: 30600 nM
Estimate against measurement, compound 4: 2.3-fold (0.36 log units) above; the measured number falls inside the stated range.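

The change from methylsulfanyl to its selenium counterpart again gives a lower number in this assay, with an at least 3.2-fold lower number from compound 3 to compound 4 (0.51 log units; beyond the scatter), so the direction of the step held on both cores shown. This does not show that the step has the same size on each core, and two cores are too few to support a general rule; the two steps compare as follows: the same change on two cores in this assay, an at least 2.1-fold lower number (0.34 log units; beyond the scatter) from compound 1 to compound 2 and an at least 3.2-fold lower number (0.51 log units; beyond the scatter) from compound 3 to compound 4; the limit leaves it open whether they differ. Each step starts from a sulfur compound that gives only a limit, so neither true size is known: the limit of > 100000 nM in this assay, at which 2 of the 4 values shown sit.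

From the compounds shown here alone, whether a longer chain on the selenium, or an amine on the same carbon, would give a lower number in this assay remains open. So does whether the step would carry over to a third core.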